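Aryl substitution pattern and agonist potency in the series

The source may report more compounds than this note shows. Statements on the series, on what has been measured and on what is new or still open speak of the compounds shown alone.

For the measured compounds named here, compound 3 `CC#CC(CC(=O)O)c1ccc(OCc2ccc3nc(-c4cccc(C)c4)cn3c2)cc1` gives 1050 nM in an assay on isolated protein for agonist activity at Free fatty acid receptor 1 (Homo sapiens) (on this read-out lower numbers stand for an effect already at smaller amounts and higher numbers for an effect only at larger amounts of compound), the highest of the three numbers measured so far. Compound 1 `CC#CC(CC(=O)O)c1ccc(OCc2ccc3nc(-c4ccccc4C)cn3c2)cc1` gives 389 nM in this assay and compound 2 `CC#CC(CC(=O)O)c1ccc(OCc2ccc3nc(-c4ccc(OC)cc4)cn3c2)cc1` gives 47 nM, so compound 3 sits a 2.7-fold higher number from compound 1 to compound 3 (0.43 log units; beyond the scatter) and a 22-fold higher number from compound 2 to compound 3 (1.35 log units; beyond the scatter).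

Compound 4 `CC#CC(CC(=O)O)c1ccc(OCc2ccc3nc(-c4ccc(C)cc4)cn3c2)cc1` differs from compound 3 in one place: 4-methylphenyl in place of 3-methylphenyl on an aromatic carbon. The two have the same atoms, joined differently.

Going by the values given here, three measured steps bear on this change. The 4-methoxyphenyl gave an 8.3-fold lower number from compound 1 to compound 2 (0.92 log units; beyond the scatter); the 3-methylphenyl of compound 3 gave a 2.7-fold higher number from compound 1 to compound 3 (0.43 log units; beyond the scatter) and a 22-fold higher number from compound 2 to compound 3 (1.35 log units; beyond the scatter). The 3-methylphenyl is thus the weakest of the three aryl groups tested, and the 4-methoxyphenyl the strongest. Among the compounds with values here, no measured pair compares a methyl with a methoxy group on the same ring position, so the size of the 4-methylphenyl effect is only bracketed. A lower number than compound 3 is expected in this assay for compound 4, probably falling between compound 1 and compound 2, so the step from compound 3 to compound 4 is estimated as an 8.8-fold lower number from compound 3 to compound 4 (0.94 log units; beyond the scatter). Compound 4 is therefore expected to give about 120 nM, with a range of 40 nM to 400 nM.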

Compound 4, half-maximal effective concentration: 507 nM
Compound 4: middle estimate off by 4.2-fold (0.63 log units), on the low side; measured number outside the range, above it.
By their numbers in this assay, from the lowest: compound 2; then compounds 1 and 4 (each within the scatter of the next); then compound 3.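

In this assay, the 4-methylphenyl in place of the 3-methylphenyl gives only a 2.1-fold lower number from compound 3 to compound 4 (0.32 log units; beyond the scatter), while the 4-methylphenyl and the 2-methylphenyl cannot be told apart, with a 1.3-fold higher number from compound 1 to compound 4 (0.12 log units; within the scatter), so among the three methylphenyl groups only the 3-methylphenyl of compound 3 stands apart. The pair with the substituent on the same ring position now isolates the exchange of methyl for methoxy, which gives an 11-fold higher number from compound 2 to compound 4 (1.03 log units; beyond the scatter), so the low number of compound 2 goes with the methoxy group and not with the ring position alone. Nothing at hand gives a reason for either difference.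

On these data alone, it remains open whether the methoxy group keeps this advantage as a 2-methoxyphenyl or 3-methoxyphenyl group, which would show whether the order seen with methyl also holds for methoxy. Also open, as far as these compounds go, is how an unsubstituted phenyl, a 4-ethoxyphenyl or a 4-hydroxyphenyl would compare with compound 2 and compound 4 in this assay.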